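This account rests on a few compounds, and the source may have more. Where it says the series, first, only, none or still open, it means among the compounds named here.

Compound 2 `O=C(CCc1cn(Cc2ccc3oc(-c4ccc(Cl)cc4)cc(=O)c3c2)nn1)Nc1ccccc1` stands with the highest of the two numbers in an assay on isolated protein for inhibition of Amine oxidase [flavin-containing] B (Homo sapiens), read by fluorescence and spectrophotometry (a higher number here means a weaker inhibitor, a lower number a stronger inhibitor), giving 32900 nM; compound 1 `O=C(CCc1cn(Cc2ccc3oc(-c4ccccc4)cc(=O)c3c2)nn1)Nc1ccc(F)cc1` gives 15600 nM in this assay, a lower number than compound 2. Compound 3 `O=C(CCc1cn(Cc2ccc3oc(-c4ccc(Cl)cc4)cc(=O)c3c2)nn1)Nc1ccc(Cl)cc1` has not yet been measured there. It differs from compound 2 by chloro in place of hydrogen on an aromatic carbon. Among the measured compounds shown here, no measured pair shows this exact change, so the step is estimated to be small, with no clear direction beyond the scatter, as a 1.4-fold lower number from compound 2 to compound 3 (0.14 log units; within the scatter). Compound 3 is therefore expected to give about 24000 nM in this assay, within a range of 9000 nM to 60000 nM.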

Compound 3, half-maximal inhibitory concentration: 32900 nM
Compound 3: middle estimate off by 1.4-fold (0.14 log units), on the low side; the range from low to high includes it.
By their numbers in this assay, from the lowest: compound 1; then compounds 2 and 3 (each within the scatter of the next).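

In this assay, replacing hydrogen with chloro on the aromatic carbon para to a large group, which turns phenylcarbamoyl into (4-chlorophenyl)carbamoyl, gives no change at the digits printed from compound 2 to compound 3 (within the scatter). This is the only single change that can be read among these compounds, and at this position, with the rest of the molecule held fixed, chloro leaves the number unmoved. Nothing at hand accounts for this result. Going by these compounds, whether an amine or a carboxylic acid in the same place would shift the number remains open. So does whether chloro would behave the same way in compound 1.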